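Compound 4: a second change with no measured step

This account rests on a few compounds, and the source may have more. Where it says the series, first, only, none or still open, it means among the compounds named here.

Compound 1 (`COc1cc(-c2cc(=O)c3ccc(O)cc3o2)cc(OC)c1OC`): 26.4 nM
Compound 2 (`COc1ccc(-c2cc(=O)c3ccc(OCCCCN4CCC(C)CC4)cc3o2)cc1`): 28.1 nM
Compound 3 (`COc1ccc(-c2cc(=O)c3ccc(OCCCCN4CCC(CCO)CC4)cc3o2)cc1`): 23.2 nM

In a functional assay, read by spectrophotometry (on this read-out higher numbers stand for an effect only at larger amounts of compound and lower numbers for an effect already at smaller amounts), compound 2 gives 28.1 nM, and this value lies within the usual scatter of the other two, so none of the three stands apart.

The next compound to be measured is compound 4 (`COc1ccc(-c2cc(=O)c3ccc(OCCCCCN4CCC(CCO)CC4)cc3o2)cc1`). The change from compound 2 is (4-(2-hydroxyethyl)piperidin-1-yl)methyl in place of 4-methylpiperidin-1-yl on a saturated chain carbon, four bonds along the chain from an oxygen on an aromatic ring. In words, (4-(2-hydroxyethyl)piperidin-1-yl)methyl comes in place of 4-methylpiperidin-1-yl on a saturated chain carbon, four bonds along the chain from an oxygen on an aromatic ring.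

Among the measured compounds shown here, one measured step bears on this. Compound 3 already carries the hydroxyl-bearing ring end, and the step to it is a 1.2-fold lower number from compound 2 to compound 3 (0.08 log units; within the scatter), which is small. For the measured compounds named here, the longer chain of compound 4 is a separate part of the change, and no measured step covers it. Compound 1 carries no such side chain and offers no guide.

No step beyond the scatter is therefore expected in this assay, in either direction, although the untested chain length calls for a wide range. The expected change is a 1.1-fold lower number from compound 2 to compound 4 (0.05 log units; within the scatter). For compound 4 the estimated value is 25 nM, with an expected range of 10 nM to 60 nM.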

Compound 4, half-maximal effective concentration: 27.9 nM
Compound 4: middle estimate off by 1.1-fold (0.05 log units), on the low side; low and high end bracket the measured number.
By their numbers in this assay, from the lowest: compounds 3, 1, 4 and 2 (each within the scatter of the next).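

In this assay, putting (4-(2-hydroxyethyl)piperidin-1-yl)methyl in place of 4-methylpiperidin-1-yl gives a 1.0-fold lower number from compound 2 to compound 4 (0.00 log units; within the scatter) so this place, on a saturated chain carbon, four bonds along the chain from an oxygen on an aromatic ring, takes the larger group and its added hydrogen-bond donor with no step beyond the scatter. Among the compounds shown here, compound 3 and compound 4 carry the same ring end and differ only in chain length, and their comparison gives a 1.2-fold higher number from compound 3 to compound 4 (0.08 log units; within the scatter) so the longer chain, which the earlier compounds did not cover, also stays within the scatter. Across compound 2, compound 3 and compound 4, these changes to the ring end and the chain length leave every number within the scatter of the others, and nothing on hand says why.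

From the compounds shown here alone, whether a shorter chain, or a carboxylic acid or a primary amine in place of the hydroxyl, would also stay within the scatter remains open. Going by these compounds, compound 1 differs from the others in more than one place, so what the side chain contributes to the shared core also remains open.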